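A few compounds are considered here, and "the series" means these few. Any claim that something is new, unique, unknown or untested is made for them only; others in the source may bear on it.

Compound 2 `C=CCOc1cccc(-c2nc(-c3ccccc3CC)n[nH]2)c1` gives 0.12 mg/kg in a functional assay on the whole organism (Cricetulus griseus) with Cricetinae gen. sp. as the target; on this read-out higher numbers stand for an effect only at larger amounts of compound and lower numbers for an effect already at smaller amounts; compound 1 `CCc1ccccc1-c1n[nH]c(-c2ccccc2)n1` gives 0.15 mg/kg in this assay, and the two values stand within the scatter of each other. Among the compounds with values here, the one measured step at this carbon, a 1.3-fold lower number from compound 1 to compound 2 (0.10 log units; within the scatter), stayed within the scatter. Compound 3 `CCc1ccccc1-c1n[nH]c(-c2cccc(-c3ccccc3)c2)n1` carries phenyl in place of allyloxy on an aromatic carbon. Since a 1.3-fold lower number from compound 1 to compound 2 (0.10 log units; within the scatter) remained within the scatter, no step beyond the scatter is expected in this assay, and a step of a 1.3-fold higher number from compound 2 to compound 3 (0.10 log units; within the scatter) is estimated. For compound 3 the value in this assay is estimated at 0.15 mg/kg, with a range from 0.05 mg/kg to 0.45 mg/kg.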

Compound 3, dose for half-maximal effect: 10 mg/kg
Estimate against measurement, compound 3: 67-fold (1.82 log units) below; the measured number lies above the stated range.
By their numbers in this assay, from the lowest: compounds 2 and 1 (each within the scatter of the next); then compound 3.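

Phenyl in place of allyloxy gives an 83-fold higher number from compound 2 to compound 3 (1.92 log units; beyond the scatter) and phenyl in place of hydrogen gives a 67-fold higher number from compound 1 to compound 3 (1.82 log units; beyond the scatter) in this assay. This carbon is therefore not indifferent to what it carries: allyloxy and hydrogen stand within the scatter of each other, while phenyl goes with a large rise in the dose needed. Nothing measured here bears on the reason for this.

From the compounds shown here alone, whether the aromatic ring itself goes with the higher number stays open. A cyclohexyl, a benzyloxy or a longer alkoxy chain at this carbon could separate these readings.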